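Removing One Acetyl Group: What to Expect for Compound 4

This account rests on a few compounds, and the source may have more. Where it says the series, first, only, none or still open, it means among the compounds named here.

Measured compounds:
Compound 1, `CCCCCCCCO[C@@H]1O[C@@H](C)[C@H](OC(=O)CCCCC)[C@@H](O[C@@H]2O[C@@H](C)[C@H](OC(C)=O)[C@@H](O[C@@H]3O[C@@H](C)[C@H](OC(C)=O)[C@@H](OC(C)=O)[C@H]3O)[C@H]2OC(C)=O)[C@H]1O`: 14 uM
Compound 2, `CCCCCCCCO[C@@H]1O[C@@H](C)[C@H](OC(=O)CCCCC)[C@@H](O[C@@H]2O[C@@H](C)[C@H](OC(C)=O)[C@@H](OC(C)=O)[C@H]2OC(C)=O)[C@H]1O`: 9 uM
Compound 3, `CCCCCCCCO[C@@H]1O[C@@H](C)[C@H](OC(=O)CCCCC)[C@@H](O[C@@H]2O[C@@H](C)[C@H](OC(C)=O)[C@@H](O[C@@H]3O[C@@H](C)[C@H](OC(C)=O)[C@@H](O)[C@H]3O)[C@H]2OC(C)=O)[C@H]1O`: 25 uM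

The three measured compounds share an octyl chain at one end and a hexanoyl ester on the first sugar unit, and they were tested in a functional assay on Lu1 cells (Homo sapiens) for antiproliferative activity, read by MTT assay, with a stated time of 48 h; a higher number here means that more compound is needed for the effect, a lower number that less compound is needed. Compound 1 gives 14 uM, and compound 3, which carries hydrogen in place of acetyl on an oxygen on a saturated carbon, gives 25 uM. The step between them, a 1.8-fold higher number from compound 1 to compound 3 (0.25 log units; within the scatter), is small enough to sit inside the usual spread of repeated measurements. Compound 2 gives 9 uM in this assay; how its core differs from that of compound 1 is not broken down here, and its number lies within the scatter of that of compound 1, while the number for compound 3 is the higher of the two when set against compound 2.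

Compound 4, `CCCCCCCCO[C@@H]1O[C@@H](C)[C@H](OC(=O)CCCCC)[C@@H](O[C@@H]2O[C@@H](C)[C@H](O)[C@@H](OC(C)=O)[C@H]2OC(C)=O)[C@H]1O`, has not yet been measured. It differs from compound 2 by hydrogen in place of acetyl on an oxygen on a saturated carbon, the same change, at the same kind of place, that turns compound 1 into compound 3. Because a 1.8-fold higher number from compound 1 to compound 3 (0.25 log units; within the scatter) was a small step, the expectation is that the step from compound 2 to compound 4 is also modest, a 1.7-fold higher number from compound 2 to compound 4 (0.22 log units; within the scatter), with a sizeable spread around it. In this assay compound 4 is therefore expected to give about 15 uM, most likely between 7 uM and 35 uM.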

Compound 4, concentration for half-maximal effect: 9 uM
Compound 4: the middle estimate sits 1.7-fold (0.22 log units) above what was measured, within the range that was stated.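

In this assay, the change from acetoxy to hydroxy on the core of compound 2 gives no change at the digits printed from compound 2 to compound 4 (within the scatter), and this step can be set directly beside the one seen earlier on the larger core: the same change on two cores in this assay, a 1.8-fold higher number (0.25 log units; within the scatter) from compound 1 to compound 3 and no change at the digits printed (within the scatter) from compound 2 to compound 4, 1.8-fold (0.25 log units) apart, within the scatter of two such steps Both steps and the gap between them lie within the scatter, so on these two cores the change travels as one that leaves the number about where it stood, and neither core gives a sign that it responds to the change differently. Among these compounds, this rests on only two pairs of compounds, however, so it does not show that the change would behave in the same way on any other core or at any other acetoxy group, and it gives no reason for the small size of either step.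

The compounds shown leave open what happens when a different group takes the place of this hydroxy, such as an amine or a methyl ether, and whether a step beyond the scatter could be reached that way. They also leave open how the numbers would respond if the octyl chain or the hexanoyl ester, which all four compounds share, were replaced by a shorter or longer chain.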